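Testing the mirror image of compound 3

The source may hold more compounds than are shown below. What is called first, only, known or untested is meant among the compounds shown, and "the series" means these compounds.

In a functional assay on A549 cells (Homo sapiens) for cytotoxicity, read by MTT assay, with a stated time of 48 h (on this read-out lower numbers stand for stronger inhibition and higher numbers for weaker inhibition), three related compounds have been measured so far. Compound 1 `COc1cc([C@@H]2C[C@]2(CO)C(=O)NCc2ccc(C)cc2)cc(OC)c1OC` gives 10500 nM, and compound 2 `CCOC(=O)[C@]1(C(=O)Nc2ccccc2)C[C@H]1c1cc(OC)c(OC)c(OC)c1` gives 37300 nM. Compound 3 `COc1cc([C@H]2C[C@@]2(CO)C(=O)Nc2ccccc2)cc(OC)c1OC` reaches only a limit of the assay, > 100000 nM, and this is not an exact number.

Compound 4 `COc1cc([C@@H]2C[C@]2(CO)C(=O)Nc2ccccc2)cc(OC)c1OC` is the next to be considered. The change is purely one of spatial arrangement: the two compounds have the same atoms and bonds and differ only in configuration as drawn: 2 of 2 stereo elements differ (all stereocentres are inverted: mirror images); a stereocentre at a saturated ring carbon is drawn R in compound 3 and S in compound 4; a stereocentre at a saturated ring carbon is drawn R in compound 3 and S in compound 4. The two compounds are therefore mirror images, built from the same atoms and bonds.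

Among the compounds with values here, no measured pair of mirror images is available here, so the size of this step cannot be read from earlier results. Mirror images can behave very differently in cells, yet they can also behave alike. A moderate gain in this assay seems the likeliest outcome, although compound 4 could also end at the limit. The expected change is an at least 2.5-fold lower number from compound 3 to compound 4 (0.39 log units; beyond the scatter). For compound 4 the estimated value is 40000 nM, with an expected range from 10000 nM to 100000 nM.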

Compound 4, half-maximal inhibitory concentration: 24100 nM
Beside the measured number, compound 4's estimate is 1.7-fold (0.22 log units) above it; measured number inside the range.
By their numbers in this assay, from the lowest: compound 1; then compounds 4 and 2 (each within the scatter of the next). At a limit, above all of these: compound 3.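

In this assay, inverting both stereocentres gives an at least 4.1-fold lower number from compound 3 to compound 4 (0.61 log units; beyond the scatter), the first measured sign that the arrangement in space matters here, and only configuration can account for it: the fact that compounds 3 and 4 differ only in the configuration as drawn

Compound 3 stands at a limit and not at an exact number, so the full size of this step stays unknown: the limit of > 100000 nM in this assay, at which 1 of the 4 values shown sits.

With compound 4 as the reference, hydroxymethyl in place of ethoxycarbonyl gives a 1.5-fold lower number from compound 2 to compound 4 (0.19 log units; within the scatter), so that swap shows no clear effect, while phenyl in place of 4-methylbenzyl on an amide-type nitrogen gives a 2.3-fold higher number from compound 1 to compound 4 (0.36 log units; beyond the scatter), a modest difference.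

Going by these compounds, it remains open whether inverting both stereocentres would matter as much with 4-methylbenzyl on that nitrogen. On these data alone, how a carboxylic acid or an amine in place of hydroxymethyl on the saturated ring carbon would read also remains open.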